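Furan to oxolane on the shared core in macrophage cells

The source may hold more compounds than are shown below. What is called first, only, known or untested is meant among the compounds shown, and "the series" means these compounds.

Measured compounds:
compound 1 `CC(C)Nc1nc(NCc2ccco2)c2ccccc2n1` — 17000 nM
compound 2 `c1coc(CNc2nc(NC3CCCC3)nc3ccccc23)c1` — "not determined" (no result reported)

The study examines small changes to a shared core in an ADME assay on J774.A1 cells (Mus musculus) for inhibition, read by MTT assay, with a stated time of 72 h; on this read-out lower numbers stand for an effect already at smaller amounts and higher numbers for an effect only at larger amounts of compound. Within the data shown here, compound 1 is the only compound with a number in this assay, so it stands alone there; compound 2 carries no result in this assay and gives no comparison. Compound 3 `CC(C)Nc1nc(NCC2CCCO2)c2ccccc2n1` is the unmeasured partner of compound 1. The change from compound 1 to compound 3 is oxolan-2-yl in place of furan-2-yl on a saturated chain carbon bound to a nitrogen on an aromatic ring. Among the measured compounds shown here, no step between two measured compounds is available, so the size of this step cannot be read from the data. The change keeps the ring size and the count of hetero atoms, donors and acceptors; the aromatic ring becomes non-aromatic. The step from compound 1 to compound 3 is expected to stay within the scatter, as a 1.2-fold higher number from compound 1 to compound 3 (0.07 log units; within the scatter). Compound 3 is therefore estimated at 20000 nM, with a range from 8000 nM to 50000 nM.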

Compound 3, half-maximal effective concentration: 46000 nM
Compound 3: middle estimate off by 2.3-fold (0.36 log units), on the low side; measured number inside the range.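

In this assay, replacing furan-2-yl with oxolan-2-yl on a saturated chain carbon bound to a nitrogen on an aromatic ring gives a 2.7-fold higher number from compound 1 to compound 3 (0.43 log units; beyond the scatter) and so shows that this position responds to the change, though only modestly. The two groups match in heavy atoms, hetero atoms, donors, acceptors and ring size, and differ in that one ring is aromatic and the other is non-aromatic. Nothing available explains why the number moves in this direction.

As far as these compounds go, whether a phenyl ring, a morpholine ring or a longer chain at this place would shift the number further remains open. Among these compounds, with only this one pair, it is also unknown whether the same change would give a similar step with a cyclopentylamino group on the shared core.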